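Swapping 3,4,5-trimethoxyphenyl for thiophen-2-yl

A few compounds are considered here, and "the series" means these few. Any claim that something is new, unique, unknown or untested is made for them only; others in the source may bear on it.

Measured in a functional assay on HCT-116 cells (Homo sapiens) for inhibition, read by sulforhodamine B assay, with a stated time of 48 h, tested at 50 uM; on this read-out lower numbers stand for less inhibition of growth and higher numbers for more inhibition of growth at the one concentration tested:
- compound 1 `COc1ccc(/C=C/C(=O)/C=C/c2ccc(OCc3cn(CCCOc4cc(=O)oc5ccccc45)nn3)c(OC)c2)cc1OC`, 67%
- compound 2 `COc1cc(/C=C/C(=O)/C=C/c2cc(OC)c(OC)c(OC)c2)ccc1OCc1cn(CCCOc2cc(=O)oc3ccccc23)nn1`, 76%

Among the compounds with values here, compound 2 stands level with compound 1, its only comparison, within the scatter. Within the data shown here, the one measured step, methoxy in place of hydrogen on an aromatic carbon, is a number 9 percentage points higher from compound 1 to compound 2 (within the scatter). Compound 3 `COc1cc(/C=C/C(=O)/C=C/c2cccs2)ccc1OCc1cn(CCCOc2cc(=O)oc3ccccc23)nn1` is still unmeasured, and its change is larger: thiophen-2-yl in place of 3,4,5-trimethoxyphenyl on a double-bonded chain carbon bound to a double-bonded chain carbon. Among the measured compounds shown here, only that single step bears on it, and it gives weak guidance, as it touches one methoxy and not a whole group. In this assay a modest drop is expected, a number 14 percentage points lower from compound 2 to compound 3 (beyond the scatter). The estimate for compound 3 is 62% (42% to 80%) .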

Compound 3, percent growth inhibition at one concentration: 58%
Beside the measured number, compound 3's estimate is 4 percentage points above it; the measured number falls inside the stated range.
By their numbers in this assay, from the lowest: compounds 3, 1 and 2 (each within the scatter of the next, the first and the last beyond it).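

In this assay, within the data shown here, this position on a double-bonded chain carbon bound to a double-bonded chain carbon gives the first step beyond the scatter when thiophen-2-yl replaces 3,4,5-trimethoxyphenyl, with a number 18 percentage points lower from compound 2 to compound 3 (beyond the scatter). When thiophen-2-yl replaces 3,4-dimethoxyphenyl instead, the result is a number 9 percentage points lower from compound 1 to compound 3 (within the scatter), so the outcome of the swap depends on which group leaves. No supporting measurement explains why these two steps differ. Going by these compounds, it remains open how an unsubstituted phenyl ring or a furan-2-yl ring would behave at this position. An aminomethyl group on the thiophene ring is equally untested by these compounds.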